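Rearranged thioamide chain on the ring nitrogen

The source may hold more compounds than are shown below. What is called first, only, known or untested is meant among the compounds shown, and "the series" means these compounds.

Compound 1 `CC1=NN(CC(C)C(=N)S)C(=O)CC1`: in a functional assay on the whole organism (stomach) for inhibition, with Rattus norvegicus as the target, at a dose of 100 mg/kg by the intraduodenal route (on this read-out lower numbers stand for less inhibition and higher numbers for more inhibition at the one dose given (going by the name of the read-out)), compound 1 gives 15.6%.
Compound 2 `CC(CC(=N)S)N1N=C(c2ccccc2)CCC1=O`: in this assay compound 2 gives 9.2%.

Compound 2 and compound 1 differ at several places at once, and the two numbers lie within the scatter of each other, so no order between them can be read.

Compound 3 `CC(CN1N=C(c2ccccc2)CCC1=O)C(=N)S` is the next member. It differs from compound 2 in this way: a group of 6 heavy atoms (4 carbon, 1 nitrogen, 1 sulfur; no ring) in place of a group of 6 heavy atoms (4 carbon, 1 nitrogen, 1 sulfur; no ring), on an amide-type nitrogen in a ring. Among the measured compounds shown here, no measured pair separates the effect of such a change, so the expected step in this assay is a number 1.8 percentage points higher from compound 2 to compound 3 (within the scatter), none beyond the scatter. For compound 3 the estimate in this assay is 11%, between 0% and 26%.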

Compound 3, a percentage reported as inhibition, in the whole organism at one dose (the size of the read-out at that dose, not a potency): 28.2%
Beside the measured number, compound 3's estimate is 17.2 percentage points below it, and the stated range ends below it.
By their numbers in this assay, from the lowest: compounds 2 and 1 (each within the scatter of the next); then compound 3.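

In this assay the arrangement of the chain on the amide-type nitrogen matters on its own: the same atoms joined differently give a number 19 percentage points higher from compound 2 to compound 3 (beyond the scatter) with the rest of the structure unchanged. With that chain held, phenyl in place of methyl on a carbon with a double bond to nitrogen gives a number 12.6 percentage points higher from compound 1 to compound 3 (beyond the scatter) and so the group at that place also counts, which compound 1 and compound 2 could not show. As far as these compounds go, whether a longer chain or a carboxylic acid on that nitrogen would shift the number further stays open. No measurement at hand accounts for either step.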